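A few compounds are considered here, and "the series" means these few. Any claim that something is new, unique, unknown or untested is made for them only; others in the source may bear on it.

In a functional assay on L1210 cells (Mus musculus) for inhibition (a lower number here means a stronger inhibitor, a higher number a weaker inhibitor), three compounds have been measured. Compound 1 `C=C1[C@@H](O)[C@H](n2cnc3c(N(C)C)nc(N)nc32)O[C@@H]1CO` gives only a limit of the assay, > 500000 nM. Compound 2 `C=C1[C@@H](O)[C@H](n2cnc3c(OC)nc(N)nc32)O[C@@H]1CO` gives 446000 nM. Compound 3 `C=C1[C@H](n2cnc3c(N(C)C)nc(N)nc32)O[C@H](CO)[C@H]1O` gives 454000 nM.

Compound 1 and compound 2 share one core. Compound 3 is built from the same atoms joined differently, and how its core differs from that of compound 1 is not broken down here. Compound 2 differs from compound 1 by methoxy in place of dimethylamino on an aromatic carbon, and that change gave an at least 1.1-fold lower number from compound 1 to compound 2 (0.04 log units; that floor lies within the scatter), a step the limit of compound 1 does not let one size exactly. The same kind of change leads from compound 3 to the unmeasured compound 4 `C=C1[C@H](n2cnc3c(OC)nc(N)nc32)O[C@H](CO)[C@H]1O`, namely (methoxy in place of dimethylamino on an aromatic carbon), at a place described in the same words in both pairs. The values of compound 2 and compound 3 lie within the scatter of each other. A small step is expected again, because an at least 1.1-fold lower number from compound 1 to compound 2 (0.04 log units; that floor lies within the scatter) stayed within the scatter. Compound 4 is therefore estimated to give about 420000 nM in this assay, with a likely range from 220000 nM to 800000 nM. That estimate corresponds to an expected step of a 1.1-fold lower number from compound 3 to compound 4 (0.03 log units; within the scatter).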

Compound 4, half-maximal inhibitory concentration: 10000 nM
The estimate for compound 4 lay 42-fold (1.62 log units) above the measured number, and the stated range ends above it.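

In this assay, methoxy in place of dimethylamino on an aromatic carbon gave a 45-fold lower number from compound 3 to compound 4 (1.66 log units; beyond the scatter), so on the core of compound 3 this change matters a great deal. This does not show that the change carries over from one core to another with the same size, as the two results cannot be told apart or shown to agree: the same change on two cores in this assay, an at least 1.1-fold lower number (0.04 log units; that floor lies within the scatter) from compound 1 to compound 2 and a 45-fold lower number (1.66 log units; beyond the scatter) from compound 3 to compound 4; the limit leaves it open whether they differ The step on the core of compound 1 starts from a limit of the assay and not from a number, so its true size cannot be read: the limit of > 500000 nM in this assay, at which 1 of the 4 values shown sits.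

The compounds shown carry only methoxy or dimethylamino at this place, which leaves open whether a hydroxyl group, a chlorine atom or a longer chain such as ethoxy would match methoxy on either core. They also leave open whether a step this large would appear on any further core, since one measured pair cannot make a rule.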